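The source may hold more compounds than are shown below. What is called first, only, known or untested is meant among the compounds shown, and "the series" means these compounds.

Of the compounds shown here, three sharing a core have been measured in an ADME assay on L6 cells (Rattus norvegicus) for cytotoxicity, read by resazurin assay, with a stated time of 72 h; a lower number here means a stronger inhibitor, a higher number a weaker inhibitor. Compound 1 `Cc1occc1C(=O)NC(=O)c1ccccc1O` gives 16 ug/mL and compound 2 `O=C(NC(=O)c1ccccc1O)c1ccc(F)cc1` gives 38 ug/mL, the higher of these two actual numbers. Compound 3 `CS(=O)(=O)c1ccc(C(=O)NC(=O)c2ccccc2O)cc1` returns only a limit, > 100 ug/mL.

The change followed here starts from compound 2 and leads to compound 4 `CCCCOc1ccc(C(=O)NC(=O)c2ccccc2O)cc1`, with butoxy in place of fluoro on an aromatic carbon. Within the data shown here, one measured step bears on this, since it alters the same aromatic carbon, putting methylsulfonyl in place of fluoro: an at least 2.6-fold higher number from compound 2 to compound 3 (0.42 log units; beyond the scatter). On these data alone, that step ends at the limit of > 100 ug/mL in this assay, at which 1 of the 3 values shown sits, so its full size remains open. Butoxy and methylsulfonyl are different groups, however, and the direction of that step need not carry over. The only other guide is compound 1, whose value of 16 ug/mL shows that a number lower than that of compound 2 occurs among these compounds. On this thin evidence, a modest move toward a lower number is expected rather than a repeat of the rise seen with compound 3. The expected change is a 2.1-fold lower number from compound 2 to compound 4 (0.32 log units; beyond the scatter). For compound 4 the estimated value is 18 ug/mL, with an expected range of 6 ug/mL to 55 ug/mL.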

Compound 4, half-maximal inhibitory concentration: 13 ug/mL
For compound 4 the middle estimate is 1.4-fold (0.14 log units) above the measured one, and the stated range covers the measured number.
By their numbers in this assay, from the lowest: compounds 4 and 1 (each within the scatter of the next); then compound 2. At a limit, above all of these: compound 3.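

In this assay, the aromatic carbon that carries fluoro in compound 2 now shows movement in both directions, not only the rise seen with methylsulfonyl, since butoxy gives a 2.9-fold lower number from compound 2 to compound 4 (0.47 log units; beyond the scatter). Exchanging one larger group for another on this same carbon also matters a great deal, with methylsulfonyl giving way to butoxy in an at least 7.6-fold lower number from compound 3 to compound 4 (0.88 log units; beyond the scatter). On these data alone, the full size of that second step stays open, since compound 3 stands at a limit of the assay: the limit of > 100 ug/mL in this assay, at which 1 of the 4 values shown sits.

With only fluoro, methylsulfonyl and butoxy on this carbon, the compounds shown leave open whether the lower number follows the length of the chain, which methoxy or a longer hexyloxy chain would test, or needs the ether oxygen, which a plain butyl group would separate. They also leave open how an amine or a carboxylic acid on this carbon would read, so the three groups shown mark out no trend that could be extended beyond them.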